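Amide aryl change from methylsulfonyl to methoxy in series

The compounds below may be only part of what the source reports. "The series", "measured", "known", "first", "only" and "open" are said of these compounds alone.

Working notes on the series. Compound 1 `Nc1cccc(S(=O)(=O)Oc2ccc(-c3cncn3C3CCN(C(=O)c4ccc(Cl)c(C(F)(F)F)c4)CC3)cc2)c1` gives 565 nM in an assay on HEK293 cells for antagonist activity at P2X purinoceptor 7 (Homo sapiens), read by fluorescence, with a stated time of 2 h; a higher number here means a weaker inhibitor, a lower number a stronger inhibitor. Compound 2 `CS(=O)(=O)c1ccc(C(=O)N2CCC(n3cncc3-c3ccc(OS(=O)(=O)c4cccc5cnccc45)cc3)CC2)cc1` gives 25 nM in this assay. Compound 3 `CS(=O)(=O)c1ccc(C(=O)N2CCC(n3cncc3-c3ccc(OS(=O)(=O)c4cccc(C#N)c4)cc3)CC2)cc1` gives 143 nM in this assay. For the measured compounds named here, the only single-point comparison measured so far is the step of a 5.7-fold higher number from compound 2 to compound 3 (0.76 log units; beyond the scatter). Compound 3 stands second highest of the three numbers, with compound 1 above it and compound 2 below it, both gaps beyond the scatter; compound 1 differs from compound 3 in more than one place, so its value is taken only as it stands.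

Compound 4 `COc1ccc(C(=O)N2CCC(n3cncc3-c3ccc(OS(=O)(=O)c4cccc(C#N)c4)cc3)CC2)cc1` is not yet measured. It differs from compound 3 by methoxy in place of methylsulfonyl on an aromatic carbon. Going by the values given here, no measured step touches this part of the shared core; the one measured step concerns the aryl on the sulfonyl sulfur and does not bear on the present change. Among the compounds with values here, with no precedent in hand, the change is expected to move the number only modestly, in no settled direction, and the estimate stays close to compound 3. Compound 4 is therefore expected at 200 nM, with a range from 60 nM to 700 nM. The estimated step of a 1.4-fold higher number from compound 3 to compound 4 (0.15 log units; within the scatter) is expected to fall within the scatter.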

Compound 4, half-maximal inhibitory concentration: 312 nM
Compound 4: the middle estimate sits 1.6-fold (0.19 log units) below what was measured; the measured number falls inside the stated range.
By their numbers in this assay, from the lowest: compound 2; then compound 3; then compounds 4 and 1 (each within the scatter of the next).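

In this assay, methoxy in place of methylsulfonyl on the aromatic carbon para to a large group gives a 2.2-fold higher number from compound 3 to compound 4 (0.34 log units; beyond the scatter). For the compounds shown here, this is the only measured step on this aryl of the amide, and it shows that the group at this position affects the number, with the 4-methoxyphenyl carbonyl giving the weaker inhibitor of this pair. Methylsulfonyl and methoxy differ in heavy atoms, double bonds outside aromatic rings and hydrogen-bond acceptors, and this single pair cannot separate those differences, while nothing available gives a reason for the step.

Going by these compounds, it remains open whether the step keeps its direction and size when the aryl on the sulfonyl sulfur is the isoquinolin-5-yl of compound 2 rather than the 3-cyanophenyl of compound 3. Also open, on these data alone, is how the number responds at this position to other groups, such as a carboxylic acid, an amine or a longer alkoxy chain, and whether any of them matches or improves on methylsulfonyl.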